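Swapping a chloro for an ethylamino on a nicotinic ligand

The compounds below may be only part of what the source reports. "The series", "measured", "known", "first", "only" and "open" are said of these compounds alone.

Compound 2, with the structure `CN1CCC[C@H]1COc1cncc(Cl)c1`, was measured in an assay on membranes from brain for displacement of a labelled ligand from Neuronal acetylcholine receptor; alpha4/beta2 (Rattus norvegicus) (on this read-out higher numbers stand for weaker inhibition and lower numbers for stronger inhibition), and gave 0.6 nM, the lowest of the two numbers available. Within the data shown here, its only measured neighbour, compound 1, with the structure `CN1CCC[C@H]1COc1cccnc1Br`, gave in this assay 451 nM, a far higher number that lies well beyond the usual scatter, so compound 2 is clearly the stronger of the two.

Compound 3, with the structure `CCNc1cncc(OC[C@@H]2CCCN2C)c1`, has not yet been measured in this assay. Compared with compound 2 the change is ethylamino in place of chloro on an aromatic carbon. Among the measured compounds shown here, no step between two measured compounds shows what such an exchange does here. Since compound 2 gives the very strong 0.6 nM, there is room for the number to rise. The expected step in this assay, from compound 2 to compound 3, is a 10-fold higher number from compound 2 to compound 3 (1.00 log units; beyond the scatter), a rise beyond the scatter. Compound 3 is therefore estimated at 6 nM, with a range from 1 nM to 40 nM.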

Compound 3, inhibition constant: 3.7 nM
The estimate for compound 3 lay 1.6-fold (0.21 log units) above the measured number; the range from low to high includes it.
By their numbers in this assay, from the lowest: compound 2; then compound 3; then compound 1.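

In this assay, among these compounds, the step of a 6.2-fold higher number from compound 2 to compound 3 (0.79 log units; beyond the scatter) is the first direct reading of a change at this position, and it shows that ethylamino in place of chloro weakens binding beyond the scatter. The loss is limited, however: compound 3 still gives 3.7 nM even though the entering group has 3 heavy atoms instead of 1 and brings a hydrogen-bond donor, so this aromatic carbon accepts a larger group with a nitrogen attached to the ring. Nothing measured here explains why the number rises.

The compounds shown do not separate the part played by the nitrogen from that of the ethyl chain. A plain amine, a methylamino group or a longer propylamino chain at the same place would help to tell these apart.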